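From isobutyl to 3-methoxyphenyl on the ring nitrogen

The source may hold more compounds than are shown below. What is called first, only, known or untested is meant among the compounds shown, and "the series" means these compounds.

In a functional assay on MDA-MB-468 cells (Homo sapiens) for antiproliferative activity, read by MTT assay, with a stated time of 72 h (a higher number here means a weaker inhibitor, a lower number a stronger inhibitor), compound 1 `COc1cc(-c2nccn2CC(C)C)cc(OC)c1OC` gives > 100000 nM as a limit of the assay, not a number. Compound 2 `COc1cc(-c2nccn2S(=O)(=O)c2ccc(C)cc2)cc(OC)c1OC` gives > 100000 nM as a limit too. Compound 1 thus stands at the limit of > 100000 nM in this assay, at which 2 of the 3 values shown sit, and has no number of its own. Compound 3 `COc1cc(-c2nccn2-c2ccc3sccc3c2)cc(OC)c1OC` does give a number, 400 nM on the same scale. Compound 4 `COc1cccc(-n2ccnc2-c2cc(OC)c(OC)c(OC)c2)c1` differs from compound 1 as 3-methoxyphenyl in place of isobutyl on an aromatic nitrogen shows: 3-methoxyphenyl in place of isobutyl on an aromatic nitrogen. For the measured compounds named here, no measured pair tests this change, but compound 3 also carries an aromatic group on that nitrogen and reaches 400 nM here, so a clear gain is expected. The expected step in this assay is an at least 33-fold lower number from compound 1 to compound 4 (1.52 log units; beyond the scatter) towards stronger inhibition. Compound 4 is estimated at 3000 nM with a range from 300 nM to 30000 nM as expected bounds.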

Compound 4, half-maximal inhibitory concentration: 10400 nM
For compound 4 the middle estimate is 3.5-fold (0.54 log units) below the measured one; the range from low to high includes it.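

On the aromatic nitrogen, 3-methoxyphenyl in place of isobutyl gives an at least 9.6-fold lower number from compound 1 to compound 4 (0.98 log units; beyond the scatter) in this assay, so this one change is enough to bring the compound off the limit. The size of that step is only a lower bound because compound 1 holds a limit of the assay and not a number: the limit of > 100000 nM in this assay, at which 2 of the 4 values shown sit. Compound 4, at 10400 nM, still gives a higher number than compound 3, at 400 nM, so the two aromatic groups on this nitrogen do not reach the same level. Open, going by these compounds, is how an unsubstituted phenyl, or a phenyl bearing an amine or a carboxylic acid, would compare at this nitrogen, and so whether the methoxy group of compound 4 counts for anything.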